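Isopropyl on the Ring Amine of a Pyrrolidine Nitrile

The source may hold more compounds than are shown below. What is called first, only, known or untested is meant among the compounds shown, and "the series" means these compounds.

Compound 1, `N#C[C@@]1(NC(=O)[C@@H](CC(=O)N2CCOCC2)CC2CCCCC2)CCNC1`, gives 123 nM. Compound 2, `N#C[C@H](CCc1ccccc1)NC(=O)[C@@H](CC(=O)N1CCOCC1)CC1CCCCC1`, gives 25 nM. Compound 3, `N#C[C@@]1(NC(=O)[C@@H](CC(=O)N2CCOCC2)CC2CCc3ccccc3C2)CCN(C2CCCCC2)C1`, gives 5.4 nM.

In an assay on isolated protein for inhibition of cathepsin S (Homo sapiens) (on this read-out lower numbers stand for tighter binding and higher numbers for weaker binding), compound 1 stands at the highest of the three numbers. Its gap to compound 2, the nearest of the three, lies beyond the scatter, and its gap to compound 3 is wider still. Compound 4, `CC(C)N1CC[C@@](C#N)(NC(=O)[C@@H](CC(=O)N2CCOCC2)CC2CCCCC2)C1`, has not been measured in this assay. It differs from compound 1 in one place: isopropyl in place of hydrogen on an amine nitrogen in a ring. Among the compounds with values here, no measured pair in this set makes this exact change, so the size of the step has to be guessed. Compound 3 carries a substituent on the same ring amine and shows the lowest number of the set, though it also differs from compound 1 elsewhere, so it is no clean guide. For compound 4 the expected result in this assay is a move to a lower number, a 3.5-fold lower number from compound 1 to compound 4 (0.55 log units; beyond the scatter). Compound 4 is therefore estimated at 35 nM, with a range from 10 nM to 120 nM.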

Compound 4, dissociation constant: 60.6 nM
Estimate against measurement, compound 4: 1.7-fold (0.24 log units) below; the range from low to high includes it.
By their numbers in this assay, from the lowest: compound 3; then compound 2; then compound 4; then compound 1.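

In this assay, within the data shown here, the change gives a 2.0-fold lower number from compound 1 to compound 4 (0.31 log units; beyond the scatter) as a modest step, and this is the first reading of the ring amine in which nothing else differs. It shows that this nitrogen, two ring bonds from the ring atom that bears the cyano group, takes isopropyl in place of hydrogen with a small gain in binding rather than a loss, which compound 3 could not show because it also differs elsewhere. No measurement at hand accounts for the size or direction of this step.

How much the substituent on the same ring amine in compound 3 contributes to its number remains unresolved. Also open, as far as these compounds go, is whether a methyl, a longer alkyl chain or an acetyl group on this nitrogen would move the number further or reverse the step.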